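A few compounds are considered here, and "the series" means these few. Any claim that something is new, unique, unknown or untested is made for them only; others in the source may bear on it.

In a functional assay on A-375 cells (Homo sapiens) for antiproliferative activity, read by CCK-8 assay, with a stated time of 72 h (on this read-out lower numbers stand for stronger inhibition and higher numbers for weaker inhibition), two compounds sharing one core have been measured so far. Compound 1 `CCC(C)n1cnc2c(NCc3ccc(C(=O)Nc4ccccc4N)cc3)nc(Cl)nc21` gives 2880 nM, and compound 2 `CC(C)n1cnc2c(NCc3ccc(C(=O)Nc4ccccc4N)cc3)nc(Cl)nc21` gives 2170 nM. These two values lie within the scatter of each other, so compound 2 stands level with compound 1 on the numbers available. The unmeasured compound 3 `Nc1ccccc1NC(=O)c1ccc(CNc2nc(Cl)nc3c2ncn3C2CCCC2)cc1` keeps the core of compound 2 and alters one group, with cyclopentyl in place of isopropyl on an aromatic nitrogen. Among the compounds with values here, only one measured step bears on the group at this place, hydrogen in place of methyl on its saturated chain, and that step was a 1.3-fold lower number from compound 1 to compound 2 (0.12 log units; within the scatter). Within the data shown here, it is a small step, but it involves no ring, and no measured compound carries a ring here, so it is only a loose guide. On that single precedent, no step beyond the scatter is expected in this assay, in either direction. The expected step is a 1.1-fold higher number from compound 2 to compound 3 (0.03 log units; within the scatter). For compound 3 the estimated value is 2300 nM, with an expected range from 900 nM to 5500 nM.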

Compound 3, half-maximal inhibitory concentration: 2790 nM
Estimate against measurement, compound 3: 1.2-fold (0.08 log units) below; measured number inside the range.
By their numbers in this assay, from the lowest: compounds 2, 3 and 1 (each within the scatter of the next).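

In this assay, within the data shown here, compound 3 is the only one of the three compounds with a ring on the aromatic nitrogen, and its numbers show a 1.3-fold higher number from compound 2 to compound 3 (0.11 log units; within the scatter) and a 1.0-fold lower number from compound 1 to compound 3 (0.01 log units; within the scatter). Cyclopentyl, with 5 heavy atoms against the 3 of isopropyl, therefore stands level with both open-chain groups, isopropyl and sec-butyl, so closing the carbon chain into a five-membered ring opens no measurable gap at this place on these numbers. No measurement at hand gives a reason why these three groups cannot be told apart.

All three groups are built of carbon only, with no hydrogen-bond donors or acceptors, so the compounds shown leave open whether a group carrying nitrogen or oxygen here, such as an amine or a carboxylic acid, would stand apart from them. They also leave open whether the level seen so far would hold for a group much smaller than isopropyl, such as methyl, or for a larger ring, such as cyclohexyl or phenyl.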